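Replacing Phenyl by Hydrogen on Two Related Cores

The source may report more compounds than this note shows. Statements on the series, on what has been measured and on what is new or still open speak of the compounds shown alone.

Compound 1 `CCOC(=O)c1nnn(Cc2ccccc2)c1O` and compound 2 `CCOC(=O)c1nn(Cc2ccccc2)nc1O` are built from the same atoms joined differently; the difference between the two cores is not broken down here. In a physicochemical assay for acid dissociation, compound 1 gives 6.22, while compound 2 gives 5.14. Compound 3 `CCOC(=O)c1nn(C)nc1O` differs from compound 2 by one change, (hydrogen in place of phenyl on a saturated chain carbon bound to an aromatic nitrogen), and in this assay compound 3 gives 5.14; the measured step is no change at the digits printed from compound 2 to compound 3 (within the scatter). Compound 4 `CCOC(=O)c1nnn(C)c1O` carries the same change on the core of compound 1, namely (hydrogen in place of phenyl on a saturated chain carbon bound to an aromatic nitrogen), at the same place. This rests on the step of no change at the digits printed from compound 2 to compound 3 (within the scatter), which left the value where it was. Compound 4 is therefore expected to show a step of no change at the digits printed from compound 1 to compound 4 (within the scatter). Compound 4 is estimated at 6.22, within a range from 5.9 to 6.55.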

Compound 4, acid dissociation constant: 6.21
Compound 4: middle estimate off by 0.01 log units, on the high side, within the range that was stated.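

On the core of compound 1, this assay shows a number 0.01 log units lower from compound 1 to compound 4 (within the scatter) when hydrogen replaces phenyl on a saturated chain carbon bound to an aromatic nitrogen, just as it shows no change at the digits printed from compound 2 to compound 3 (within the scatter) on the other core. In these two pairs, then, the change carries from one core to the other and leaves the reading where it stood, but two pairs make no rule for other cores. The data give no reason why the reading stays the same.

The compounds shown carry only phenyl or hydrogen at this place. Going by these compounds, whether an amine, a carboxylic acid or a longer chain there would also leave the reading unchanged remains open.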